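From Cyclopentyl to 2-Phenylethenyl: One Untested Step

The source may hold more compounds than are shown below. What is called first, only, known or untested is meant among the compounds shown, and "the series" means these compounds.

Of the compounds shown here, two sharing one core have been tested in a functional assay on the whole organism for antagonist activity, with Mus musculus as the target; a higher number here means that more compound is needed for the effect, a lower number that less compound is needed. Compound 1 `CCCCCCCN1CCC(C(=O)Nc2cc(Cl)c(N)cc2OC)CC1` gives only a limit of the assay, > 10 mg/kg. Compound 2 `COc1cc(N)c(Cl)cc1NC(=O)C1CCN(CC2CCCC2)CC1` likewise gives only a limit, > 10 mg/kg. The step between them, a step that the two limits leave unreadable from compound 1 to compound 2, therefore cannot be read; both values sit at the limit of > 10 mg/kg in this assay, at which 2 of the 2 values shown sit. Compound 3 `COc1cc(N)c(Cl)cc1NC(=O)C1CCN(C/C=C/c2ccccc2)CC1` has not been tested. It differs from compound 2 in one place: 2-phenylethenyl in place of cyclopentyl on a saturated chain carbon bound to an amine nitrogen in a ring. Within the data shown here, no measured step involves a 2-phenylethenyl group, so nothing here shows how large a move to expect in this assay, or in which direction, beyond the scatter. Among the measured compounds shown here, the only guidance is that compound 2 itself gave no readable number. On that thin basis compound 3 is estimated at 8 mg/kg, within a range from 2 mg/kg to 30 mg/kg. The step this estimate implies, an at least 1.2-fold lower number from compound 2 to compound 3 (0.09 log units; that floor lies within the scatter), is expected to carry wide uncertainty.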

Compound 3, dose for half-maximal effect: > 10 mg/kg
Compound 3: no number, only a limit (the forecaster's own chance of this, stated with the estimate: 50%); at least 1.2-fold (0.09 log units) between middle value and limit.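

In this assay compound 3 gives only a limit, > 10 mg/kg. Its steps from compound 1 and compound 2 therefore cannot be read: the limit of > 10 mg/kg in this assay, at which 3 of the 3 values shown sit.

The compounds shown leave open whether any group on a saturated chain carbon bound to an amine nitrogen in a ring gives a readable number in this assay.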